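Methylating the Hydroxy Group of Compound 3

The source may hold more compounds than are shown below. What is called first, only, known or untested is meant among the compounds shown, and "the series" means these compounds.

Compound 1 `O=C(Nc1ccc(Sc2nc3ccccc3s2)c(Cl)c1)c1cccc(Br)c1`: in an assay for inhibition of HSP60/HSP10 (Homo sapiens), with a stated time of 60 min (on this read-out lower numbers stand for stronger inhibition and higher numbers for weaker inhibition), compound 1 gives > 100000 nM, a limit of the assay.
Compound 2 `COc1ccccc1C(=O)Nc1ccc(Sc2nc3ccccc3s2)c(Cl)c1`: compound 2 gives > 100000 nM, again only a limit.
Compound 3 `O=C(Nc1ccc(Sc2nc3ccccc3s2)c(Cl)c1)c1cc(Br)ccc1O`: compound 3 gives > 100000 nM, likewise a limit.

Compound 3 therefore stands where every measured member of the set stands, at the limit of > 100000 nM in this assay, at which 3 of the 3 values shown sit. The steps a step that the two limits leave unreadable from compound 1 to compound 2, a step that the two limits leave unreadable from compound 1 to compound 3 and a step that the two limits leave unreadable from compound 2 to compound 3 cannot be sized, since each ends at a limit. Compound 4 `COc1ccc(Br)cc1C(=O)Nc1ccc(Sc2nc3ccccc3s2)c(Cl)c1` carries the change (methyl in place of hydrogen on an oxygen on an aromatic ring). For the measured compounds named here, no measured step bears readably on this change, so nothing points to a gain beyond the scatter. Compound 4 is expected to give about 100000 nM, with a range from 30000 nM to 300000 nM, most probably again only a limit. The expected step is a number no higher from compound 3 to compound 4 (the limit leaves the size open).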

Compound 4, half-maximal inhibitory concentration: > 100000 nM
Compound 4: a limit, no number (the forecaster's own chance of this, stated with the estimate: 85%); the middle value lies on the limit itself.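

For the compounds shown here, compound 4 ends at a limit, as do compound 1, compound 2 and compound 3, so no step among them can be read. From the compounds shown here alone, whether methoxy in place of hydroxy changes anything in this assay stays open.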